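Halogen swap on the aryl of compound 3

The source may report more compounds than this note shows. Statements on the series, on what has been measured and on what is new or still open speak of the compounds shown alone.

Three compounds of the series have numbers in a functional assay on HT-29 cells (Homo sapiens) for cytotoxicity, read by MTT assay, with a stated time of 72 h; a lower number here means a stronger inhibitor, a higher number a weaker inhibitor. Compound 1 `Fc1cc(Nc2cc(Nc3cccc(Cl)c3)ncn2)ccc1Oc1ccncc1-c1cccnc1` gives 690 nM, compound 2 `Fc1ccc(Nc2cc(Nc3ccc(Oc4ccncc4-c4cccnc4)c(F)c3)ncn2)cc1` gives 330 nM, and compound 3 `Cn1c(=O)c(C(=O)Nc2ccc(Oc3ccncc3-c3cccnc3)c(F)c2)nn(-c2ccccc2F)c1=O` gives 2100 nM, the highest of the three, its nearest neighbour being compound 1. For the measured compounds named here, the only single-place step so far, a 2.1-fold lower number from compound 1 to compound 2 (0.32 log units; beyond the scatter), concerns a halogenated phenyl on a nitrogen and was modest. Compound 4 `Cn1c(=O)c(C(=O)Nc2ccc(Oc3ccncc3-c3cccnc3)c(F)c2)nn(-c2ccc(Cl)cc2)c1=O` differs from compound 3 by 4-chlorophenyl in place of 2-fluorophenyl on an aromatic nitrogen. Going by the values given here, the one measured step bears only loosely on this change, so in this assay no step beyond the scatter is expected, with perhaps a slight lowering as a 1.2-fold lower number from compound 3 to compound 4 (0.09 log units; within the scatter). Compound 4 is therefore estimated at 1700 nM, within 700 nM to 4500 nM.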

Compound 4, half-maximal inhibitory concentration: 440 nM
Compound 4: the middle estimate sits 3.9-fold (0.59 log units) above what was measured; the whole stated range lies above it.
By their numbers in this assay, from the lowest: compounds 2, 4 and 1 (each within the scatter of the next, the first and the last beyond it); then compound 3.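

In this assay, the group on the aromatic nitrogen proves a responsive position: 4-chlorophenyl in place of 2-fluorophenyl gives a 4.8-fold lower number from compound 3 to compound 4 (0.68 log units; beyond the scatter) on an otherwise unchanged compound. This change alters both the halogen and its place on the phenyl, so the step cannot be assigned to either alone. No measured property bears on this step.

On these data alone, how plain phenyl, 2-chlorophenyl or 4-fluorophenyl would read here remains open, and would separate halogen from place. Whether a phenyl carrying an amine or a carboxylic acid would follow the same trend is also unknown.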